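The compounds below may be only part of what the source reports. "The series", "measured", "known", "first", "only" and "open" are said of these compounds alone.

In an assay on a cell-free system (plasma) for inhibition of Dipeptidyl peptidase 4 (Rattus norvegicus), read by fluorescence (a higher number here means a weaker inhibitor, a lower number a stronger inhibitor), compound 1 `N#Cc1ccc(CN[C@@H]2CN[C@H](C(=O)N3CCSC3)C2)cc1` gives 34.3 nM. Compound 2 `CC(C)N(Cc1ccc(C#N)cc1)[C@@H]1CN[C@H](C(=O)N2CCSC2)C1` gives 12.5 nM, and compound 3 `N#Cc1ccc(CN(Cc2ccc(C#N)cc2)[C@@H]2CN[C@H](C(=O)N3CCSC3)C2)cc1` gives 9.3 nM, the lowest number of the three; the gap from compound 3 to compound 2 lies within the scatter, while the gap to compound 1 lies beyond it. The steps leading to compound 3 show that putting any substituent on the amine nitrogen helps: a 2.7-fold lower number from compound 1 to compound 2 (0.44 log units; beyond the scatter) and a 3.7-fold lower number from compound 1 to compound 3 (0.57 log units; beyond the scatter), whereas a 1.3-fold lower number from compound 2 to compound 3 (0.13 log units; within the scatter), so the exact substituent has mattered little so far.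

Compound 4 `CCOC(=O)CN(Cc1ccc(C#N)cc1)[C@@H]1CN[C@H](C(=O)N2CCSC2)C1` differs from compound 3 in one place: ethoxycarbonyl in place of 4-cyanophenyl on a saturated chain carbon bound to an amine nitrogen. The amine nitrogen keeps one 4-cyanobenzyl and still carries a second substituent, so compound 4 is expected to stay near compound 2 and compound 3 rather than fall back to compound 1, with the estimated step of a 1.6-fold higher number from compound 3 to compound 4 (0.21 log units; within the scatter) within the scatter. For compound 4 the expected value in this assay is 15 nM, with a likely range from 7 nM to 35 nM.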

Compound 4, half-maximal inhibitory concentration: 15.3 nM
Compound 4: the middle estimate sits 1.0-fold (0.01 log units) below what was measured, and the stated range covers the measured number.
By their numbers in this assay, from the lowest: compounds 3, 2 and 4 (each within the scatter of the next); then compound 1.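

In this assay the second substituent on the amine nitrogen need not carry a ring: a 1.6-fold higher number from compound 3 to compound 4 (0.22 log units; within the scatter) and a 1.2-fold higher number from compound 2 to compound 4 (0.09 log units; within the scatter) both stay within the scatter, so compound 2, compound 3 and compound 4 cannot be ranked here. Set against the bare amine, a 2.2-fold lower number from compound 1 to compound 4 (0.35 log units; beyond the scatter) shows that (ethoxycarbonyl)methyl also gives a modest step beyond the scatter, so three quite different groups now share this result. No measurement available here explains why these groups give such similar numbers.

As far as these compounds go, it remains open whether the ester matters at all, since a carboxylic acid or a primary amide in its place could behave alike or differently. A longer chain ending in an amine, or a single methyl, would test how far this tolerance extends.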